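Methoxy in Place of Methyl on the Benzyl Ring

The source may report more compounds than this note shows. Statements on the series, on what has been measured and on what is new or still open speak of the compounds shown alone.

Three compounds have been measured in a functional assay on MGC-803 cells (Homo sapiens) for cytotoxicity, read by MTT assay, with a stated time of 72 h; a lower number here means a stronger inhibitor, a higher number a weaker inhibitor:
Compound 1, `Cc1ccc(Cn2cc(CSC(=S)N3CCN(C(N)=O)CC3)nn2)cc1`: 29900 nM
Compound 2, `CCNC(=O)N1CCN(C(=S)SCc2cn(Cc3ccc(C)cc3)nn2)CC1`: 19800 nM
Compound 3, `CCN(C)C(=O)N1CCN(C(=S)SCc2cn(Cc3ccc(C)cc3)nn2)CC1`: 8270 nM

Among the three, the lowest number belongs to compound 3. The measured steps leading to it are a 2.4-fold lower number from compound 2 to compound 3 (0.38 log units; beyond the scatter) and a 3.6-fold lower number from compound 1 to compound 3 (0.56 log units; beyond the scatter); both changes sit on the carbonyl nitrogen of the shared core. Compound 4, `CCN(C)C(=O)N1CCN(C(=S)SCc2cn(Cc3ccc(OC)cc3)nn2)CC1`, differs from compound 3 on the other side of the molecule: methoxy in place of methyl on an aromatic carbon. Among the compounds with values here, none of the measured steps touches this ring, so they offer no guide to the direction or size of this change. The expected step is therefore a 1.0-fold higher number from compound 3 to compound 4 (0.00 log units; within the scatter), within the scatter. Compound 4 is estimated at 8300 nM in this assay, with a range from 3000 nM to 23000 nM.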

Compound 4, half-maximal inhibitory concentration: 87900 nM
Compound 4: the middle estimate sits 11-fold (1.02 log units) below what was measured, outside the stated range (above it).
By their numbers in this assay, from the lowest: compound 3; then compounds 2 and 1 (each within the scatter of the next); then compound 4.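

In this assay, the substituent on the benzyl ring turns out to matter: methoxy in place of methyl gives an 11-fold higher number from compound 3 to compound 4 (1.03 log units; beyond the scatter), a larger step than a 3.6-fold lower number from compound 1 to compound 3 (0.56 log units; beyond the scatter) at the carbonyl nitrogen. The swap is small, from 1 heavy atom to 2, so even a slight edit at this place can cost much of the activity. Nothing in the data shown explains this loss.

As far as these compounds go, whether other groups on this ring, such as a chlorine atom or a hydroxyl, behave like methoxy remains open. So does whether the same swap costs as much with the carbonyl nitrogen of compound 2.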